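Dropping the ring methyl of compound 3 to give compound 4

This account rests on a few compounds, and the source may have more. Where it says the series, first, only, none or still open, it means among the compounds named here.

The series is built on a shared core carrying a dithiocarbamate side chain, and it was tested in a functional assay on MDA-MB-435S cells (Homo sapiens) for antiproliferative activity, read by MTT assay, with a stated time of 72 h; a lower number here means a stronger inhibitor, a higher number a weaker inhibitor. Compound 1 `COc1ccc2occ(CSC(=S)N(C(C)C)C(C)C)c(=O)c2c1` gives 1800 nM in this assay. Compound 2 `CN1CCN(C(=S)SCc2coc3ccccc3c2=O)CC1`, which carries a different amine on the dithiocarbamate, gives 2200 nM. Compound 3 `Cc1ccc2c(=O)c(CSC(=S)N(C(C)C)C(C)C)coc2c1` gives 240 nM, the lowest of the three numbers: compound 1 stands a good way higher, beyond the usual scatter, and compound 2 higher still, also beyond the scatter. Compound 3 is therefore the strongest inhibitor among the measured compounds.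

Compound 4 `CC(C)N(C(=S)SCc1coc2ccccc2c1=O)C(C)C` has not yet been measured. It differs from compound 3 in one place: hydrogen in place of methyl on an aromatic carbon. Among the measured compounds shown here, no pair of measured compounds differs by exactly this change, so the step has to be judged from what the three numbers show. Compound 2, which shares the unsubstituted core with compound 4 but a different amine, sits close to compound 1, well above compound 3. The loss of the methyl is expected to cost some potency, a step of modest size upward from compound 3 to compound 4, a 2.9-fold higher number from compound 3 to compound 4 (0.46 log units; beyond the scatter), but not all the way to the level of compound 2. Compound 4 is estimated at 700 nM, within a range of 250 nM to 2500 nM.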

Compound 4, half-maximal inhibitory concentration: 7900 nM
The estimate for compound 4 lay 11-fold (1.05 log units) below the measured number; measured number above the stated range.
By their numbers in this assay, from the lowest: compound 3; then compounds 1 and 2 (each within the scatter of the next); then compound 4.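

In this assay, the methyl on this aromatic carbon, meta to a fused ring and para to a fused ring, proves to carry much of the activity: losing this single carbon gives a 33-fold higher number from compound 3 to compound 4 (1.52 log units; beyond the scatter), a large step for so small a change. The methoxy of compound 1 also counts for something, since replacing it with hydrogen gives a 4.4-fold higher number from compound 1 to compound 4 (0.64 log units; beyond the scatter), a modest step, and compound 4 with its bare core stands as the weakest of the four. The amine matters on the unsubstituted core as well: diisopropylamino in place of 4-methylpiperazin-1-yl on the thiocarbonyl carbon gives a 3.6-fold higher number from compound 2 to compound 4 (0.56 log units; beyond the scatter), again a modest step.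

Nothing at hand gives a reason for the size of any of these steps. As far as these compounds go, it remains open whether an ethyl group or a chlorine atom on the aromatic carbon that bears the methyl in compound 3 would keep its potency, and whether 4-methylpiperazin-1-yl would behave the same way on a core that carries that methyl.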